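The source may report more compounds than this note shows. Statements on the series, on what has been measured and on what is new or still open speak of the compounds shown alone.

Compound 1 `CNc1nccc(N2CC[C@H](NC(=O)Nc3ccc(OC(F)(F)F)cc3)C2)n1` is the starting point of this step. For the measured compounds named here, in a physicochemical assay for solubility, measured as kinetic solubility (a higher number here means a more soluble compound, a lower number a less soluble compound), compound 1 gives 70400 nM, the highest of the three numbers so far, although compound 2 `CNc1nccc(N2CC[C@H](NC(=O)Nc3ccc(CN4CCCC4)c(C(F)(F)F)c3)C2)n1`, which gives 37400 nM in this assay, lies within the usual scatter of it, so the two cannot be ranked. Compound 3 `O=C(Nc1ccc(Cl)c(C(F)(F)F)c1)N[C@@H]1CCN(c2ccc3nncn3n2)C1` is a different matter: in this assay compound 3 gives 1000 nM, far below compound 1 and well beyond the scatter.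

Compound 4 `CNc1nccc(N2CC[C@H](NC(=O)Nc3ccc(OC)cc3)C2)n1` has not yet been measured. It differs from compound 1 in one place: methyl in place of trifluoromethyl on an oxygen on an aromatic ring. Going by the values given here, no measured pair separated by this same change exists among the three compounds, so the size of the step rests on the change itself and on where compound 1 stands. Compound 4 is expected to move in the direction of a higher number, by a step of a 1.3-fold higher number from compound 1 to compound 4 (0.13 log units; within the scatter), which is expected to stay within or only just beyond the scatter. Compound 4 is therefore estimated at 95000 nM, with a range from 40000 nM to 220000 nM.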

Compound 4, solubility: 92600 nM
The estimate for compound 4 lay 1.0-fold (0.01 log units) above the measured number; the measured number falls inside the stated range.
By their numbers in this assay, from the lowest: compound 3; then compounds 2, 1 and 4 (each within the scatter of the next, the first and the last beyond it).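

In this assay the swap of trifluoromethyl for methyl on an oxygen on an aromatic ring gives a 1.3-fold higher number from compound 1 to compound 4 (0.12 log units; within the scatter) so trifluoromethoxy and methoxy cannot be ranked on the core of compound 1. For the compounds shown here, this is the first reading of a change in one place, since the earlier compounds differed from one another in more than one place and offered no such comparison. Nothing measured here offers an explanation for this result.

The compounds shown leave open whether another group at this place, such as a longer chain like ethoxy, a free hydroxyl or an amine, would give a step beyond the scatter. Going by these compounds alone, this is the only pair carrying the change, so whether trifluoromethoxy to methoxy reads the same way on another core also remains open.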